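Methyl on the Phenolic Oxygen: Expected Binding Shift

This account rests on a few compounds, and the source may have more. Where it says the series, first, only, none or still open, it means among the compounds named here.

Of the compounds shown here, three have been measured in an assay on isolated protein for binding affinity to Alpha-1D adrenergic receptor (Rattus norvegicus), read by radioligand binding; a higher number here means a weaker inhibitor, a lower number a stronger inhibitor. Compound 1 `CCS(=O)(=O)Nc1cc(C2CCCCC2)cc2c1CCCC2c1c[nH]cn1` gives 447 nM. Compound 2 `CS(=O)(=O)Nc1cccc2c1OCCC2c1c[nH]cn1` gives 1150 nM. Compound 3 `CS(=O)(=O)Nc1c(O)ccc2c1CCCC2c1c[nH]cn1` gives 1260 nM, the highest of the three numbers; its gap to compound 2 lies within the usual scatter of repeated measurements, so those two cannot be ranked against each other, while compound 1 sits beyond the scatter and binds more strongly than compound 3.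

Compound 4 `COc1ccc2c(c1NS(C)(=O)=O)CCCC2c1c[nH]cn1` differs from compound 3 in one place: methyl in place of hydrogen on an oxygen on an aromatic ring. Everything else in the structure is kept. Going by the values given here, no measured pair in this set shares that change, so there is no direct comparison to lean on, and the three measured values offer no trend for a hydroxy to methoxy swap.

Compound 4 is therefore expected to land close to compound 3, with the step of a 1.1-fold lower number from compound 3 to compound 4 (0.06 log units; within the scatter) expected to stay within the scatter rather than move clearly in either direction. The estimate for compound 4 in this assay is 1100 nM, with a plausible range from 350 nM to 3500 nM.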

Compound 4, inhibition constant: 479 nM
For compound 4 the middle estimate is 2.3-fold (0.36 log units) above the measured one, within the range that was stated.
By their numbers in this assay, from the lowest: compounds 1 and 4 (each within the scatter of the next); then compounds 2 and 3 (each within the scatter of the next).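

Going by these compounds alone, the hydroxy to methoxy swap is the first change in this set made in one place only, and in this assay it gives a 2.6-fold lower number from compound 3 to compound 4 (0.42 log units; beyond the scatter), a modest step but one beyond the scatter. This oxygen on the aromatic ring is therefore a place where a small edit registers, and binding does not depend on keeping the hydrogen there, since the number falls once methyl takes its place. No measurement shown gives a reason for this shift.

Still open, on these data alone, is whether the shift follows the loss of the hydrogen or the arrival of the methyl, and whether a longer chain such as ethoxy, or an amine at the same place, would move the number the same way. A single step on one core also cannot say whether the same swap would act alike on another core.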